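The source may report more compounds than this note shows. Statements on the series, on what has been measured and on what is new or still open speak of the compounds shown alone.

Compound 1 `Cc1cc(C)c(CN2CCc3c(Cl)cc([C@H](CO)[C@H]4CCOC4)c(Cl)c3C2=O)c(=O)[nH]1`: 15 nM
Compound 2 `COc1cc(C)[nH]c(=O)c1CN1CCc2c(Cl)cc(-c3c(C)noc3C)c(Cl)c2C1=O`: 27 nM

Both numbers come from a functional assay on KARPAS-422 cells (Homo sapiens) for antiproliferative activity, read by resazurin assay, with a stated time of 72 h; a lower number here means a stronger inhibitor, a higher number a weaker inhibitor. They lie within the scatter of each other, so compound 2, at 27 nM, cannot be separated from compound 1, at 15 nM.

Compound 3 `COc1cc(C)[nH]c(=O)c1CN1CCc2c(Cl)cc([C@H](O)C3COC3)c(Cl)c2C1=O` is still unmeasured and keeps the rest of compound 2. The change is on an aromatic carbon, ortho to a chloro group: a group of 6 heavy atoms (4 carbon, 2 oxygen; one four-membered non-aromatic ring with 1 hetero atom) in place of a group of 7 heavy atoms (5 carbon, 1 nitrogen, 1 oxygen; one five-membered aromatic ring with 2 hetero atoms), on an aromatic carbon. The 3,5-dimethyl-1,2-oxazol-4-yl group leaves, and a group with a four-membered non-aromatic ring enters.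

Going by the values given here, no measured step in this assay shows this exchange, so the expectation is anchored only on compound 2 at 27 nM. A modest move towards a higher number is expected, and it may not clear the scatter. The expected step is a 2.2-fold higher number from compound 2 to compound 3 (0.35 log units; beyond the scatter). Compound 3 is estimated at 60 nM, with an expected range of 15 nM to 240 nM.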

Compound 3, half-maximal inhibitory concentration: 108 nM
Compound 3: the middle estimate sits 1.8-fold (0.26 log units) below what was measured, within the range that was stated.
By their numbers in this assay, from the lowest: compounds 1 and 2 (each within the scatter of the next); then compound 3.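

On the aromatic carbon ortho to a chloro group, the exchange of the 3,5-dimethyl-1,2-oxazol-4-yl group for the group with a four-membered non-aromatic ring gives, in this assay, a 4.0-fold higher number from compound 2 to compound 3 (0.60 log units; beyond the scatter). Going by these compounds alone, this is the first single-place comparison, and it shows that the read-out responds to the group at this position, although the step is modest. No measurement available here accounts for the step.

The exchange alters the ring, the hydrogen-bond donor count and the defined stereocentre together, so the share of each in the step remains unresolved. On these data alone, how an amine, a carboxylic acid or a longer alkyl chain on this aromatic carbon would read in this assay also remains open.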